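The source may report more compounds than this note shows. Statements on the series, on what has been measured and on what is new or still open speak of the compounds shown alone.

Measured compounds:
compound 1, `CC(=O)NC[C@H]1CN(c2ccc(OC[C@H](O)CNc3ccc(C#N)cc3)c(F)c2)C(=O)O1`: 69000 nM
compound 2, `CC(=O)NC[C@H]1CN(c2ccc(OC[C@@H](O)CNc3ccncc3)c(F)c2)C(=O)O1`: 17700000 nM

Of the compounds shown here, two have been measured in a physicochemical assay for solubility, read by HPLC; on this read-out lower numbers stand for lower solubility and higher numbers for higher solubility. Compound 1, `CC(=O)NC[C@H]1CN(c2ccc(OC[C@H](O)CNc3ccc(C#N)cc3)c(F)c2)C(=O)O1`, gives 69000 nM. Compound 2, `CC(=O)NC[C@H]1CN(c2ccc(OC[C@@H](O)CNc3ccncc3)c(F)c2)C(=O)O1`, gives 17700000 nM. Compound 2 stands highest of the two numbers, and its nearest neighbour, compound 1, lies a long way below it, well beyond the usual scatter of repeated measurements. Going by the values given here, since compound 1 and compound 2 differ in more than one place, no single step between them is recorded.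

The next compound to consider is compound 3, `CC(=O)NC[C@H]1CN(c2ccc(OC[C@H](O)CNc3ccncc3)c(F)c2)C(=O)O1`. Compared with compound 2, (the two compounds have the same atoms and bonds and differ only in configuration as drawn: 1 of 2 stereo elements differ; a stereocentre at a saturated chain carbon is drawn S in compound 2 and R in compound 3). In plain words, compound 3 is the same molecule drawn with the opposite handedness at one carbon of the chain, while everything else is unchanged.

Among the compounds with values here, no measured pair in this set shows what such a change alone does in this assay, so a step of modest size, in either direction, or none beyond the scatter, is the reasonable expectation. The estimated step from compound 2 to compound 3 is a 1.5-fold lower number from compound 2 to compound 3 (0.17 log units; within the scatter). Compound 3 is therefore expected to give about 12000000 nM, within a range of 3000000 nM to 40000000 nM.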

Compound 3, solubility: 24600000 nM
Compound 3: the middle estimate sits 2.1-fold (0.31 log units) below what was measured; the measured number falls inside the stated range.
By their numbers in this assay, from the lowest: compound 1; then compounds 2 and 3 (each within the scatter of the next).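

In this assay, reversing the handedness at this saturated chain carbon gives a 1.4-fold higher number from compound 2 to compound 3 (0.14 log units; within the scatter), so the pyridin-4-yl compounds show no separation by configuration at this carbon. This pair reads as a direct test of handedness alone, with no other structural change mixed in, because of one plain fact: the fact that compounds 2 and 3 differ only in the configuration as drawn. Compound 3 also turns the earlier gap between compound 1 and compound 2, which involved two differences, into a single-place comparison: with pyridin-4-yl in place of 4-cyanophenyl on the amine nitrogen, the result is a 360-fold higher number from compound 1 to compound 3 (2.55 log units; beyond the scatter), a large step that dwarfs the one seen for handedness.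

The compounds shown cannot say which feature of the swap carries this large step, the ring nitrogen of pyridin-4-yl or the loss of the nitrile; an unsubstituted phenyl or a pyridin-3-yl on the same amine nitrogen would help to separate the two. Going by these compounds alone, they also leave open whether handedness at this chain carbon would matter as little with 4-cyanophenyl on the amine nitrogen, since only one configuration of that compound appears here.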